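Cytotoxicity limits in the series and compound 4

The source may hold more compounds than are shown below. What is called first, only, known or untested is meant among the compounds shown, and "the series" means these compounds.

- compound 1 (`Cc1noc(CC2OC(=O)c3ccccc32)n1`) gives > 40000 nM (a limit)
- compound 2 (`COc1cc(OC)c2c(c1)C(C(O)c1ccc(O)cc1)OC2=O`) gives > 40000 nM (a limit)
- compound 3 (`CCC(C)Oc1ccc(C(O)C2OC(=O)c3c(OC)cc(OC)cc32)cc1`) gives > 40000 nM (a limit)

These are results in an ADME assay on RAW264.7 cells (Mus musculus) for cytotoxicity, read by MTT assay, with a stated time of 24 h, in the presence of a further agent that is not named here (a higher number here means a weaker inhibitor, a lower number a stronger inhibitor), and none of them is a number. Across the series, the record shows the limit of > 40000 nM in this assay, at which 3 of the 3 values shown sit (no exact value is available). Compound 2 therefore has only a limit as its position, with no measured value to anchor a step.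

Compound 4 (`COCCCOc1ccc(C(O)C2OC(=O)c3c(OC)cc(OC)cc32)cc1`) has 3-methoxypropyl in place of hydrogen on an oxygen on an aromatic ring of compound 2, which is hydroxy to 3-methoxypropoxy (3-methoxypropyl in place of hydrogen on an oxygen on an aromatic ring). Going by the values given here, the one measured step bearing on this change is a step that the two limits leave unreadable from compound 2 to compound 3, at the same oxygen, and it has no readable size. Compound 3, with sec-butyl there, still shows the limit > 40000 nM, so no step beyond the scatter is expected in this assay. The estimate means a step that the limit leaves unreadable from compound 2 to compound 4 as the expected step. For compound 4 the estimated value is 50000 nM, with an expected range from 25000 nM to 100000 nM, and a report as a limit only is expected.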

Compound 4, half-maximal inhibitory concentration: > 40000 nM
Compound 4 ended at the assay's limit; the forecaster's own chance of this, stated with the estimate: 90%; the middle value does not contradict the limit.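

No step can be read from compound 2 or compound 3 to compound 4, as each pair rests on limits only: the limit of > 40000 nM in this assay, at which 4 of the 4 values shown sit.

The compounds shown leave open whether any group on this oxygen gives an exact cytotoxicity value rather than a limit.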